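The source may hold more compounds than are shown below. What is called first, only, known or untested is meant among the compounds shown, and "the series" means these compounds.

Of the compounds shown here, two that share a core have been tested in an assay on isolated protein with prostaglandin F2-alpha receptor (Homo sapiens) as the target, read by FLIPR, tested at 0.1 uM; a lower number here means a weaker effect, a higher number a stronger effect of the compound at the concentration tested. Compound 1 `Cc1cn(Cc2ccc(Cl)cc2Cl)c2c(-c3nnc(NS(=O)(=O)c4cc(F)c(F)cc4F)o3)cc(F)cc12` gives 5% in this assay. Compound 2 `Cc1cn(Cc2ccc(Cl)cc2Cl)c2c(-c3nnc(NS(=O)(=O)c4ccc(Cl)c(Cl)c4)o3)cc(F)cc12` gives -15% in this assay. Among the measured compounds shown here, the one step between them, a number 20 percentage points lower from compound 1 to compound 2 (beyond the scatter), runs toward a weaker effect. Compound 2 thus stands at the lower of the two numbers, with compound 1 the nearest neighbour and above it by that step.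

Compound 3 `Cc1cn(Cc2ccc(Cl)cc2Cl)c2c(-c3nnc(NS(=O)(=O)c4ccc(F)c(F)c4)o3)cc(F)cc12` has not yet been measured. It differs from compound 2 in one place: 3,4-difluorophenyl in place of 3,4-dichlorophenyl on a sulfonyl sulfur. For the measured compounds named here, the single measured step bears on this only loosely: there the whole 2,4,5-trifluorophenyl was exchanged for 3,4-dichlorophenyl, and the present change goes part of the way back, with fluorine entering where chlorine leaves while the 3,4-difluorophenyl keeps the same arrangement on the ring. Given that, the step is expected to run upward and to be modest, a number 15 percentage points higher from compound 2 to compound 3 (beyond the scatter). Compound 3 is therefore estimated at 0% in this assay, with a range from -15% to 15%.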

Compound 3, a percentage reported as activity, at one concentration (the size of the read-out at that concentration, not a potency): 22%
Estimate against measurement, compound 3: 22 percentage points below; measured number outside the range, above it.
By their numbers in this assay, from the lowest: compound 2; then compound 1; then compound 3.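

In this assay, exchanging the two chlorines of the 3,4-dichlorophenyl for two fluorines, with the arrangement on the ring unchanged, gives a number 37 percentage points higher from compound 2 to compound 3 (beyond the scatter), so the identity of the halogen on the group carried by the sulfonyl sulfur matters on its own, something the first pair could not show because the number and arrangement of halogens changed there as well. Hydrogen in place of one fluoro on an aromatic carbon gives a number 17 percentage points higher from compound 1 to compound 3 (beyond the scatter), so among these compounds, the ring with more fluorine atoms does not give the higher number. Nothing available here explains why either step goes upward.

The compounds shown leave open whether the rise continues with fewer halogens, as with a single fluoro or a plain phenyl, or whether a different group on the ring, such as methoxy, nitrile or a carboxylic acid, would give a higher number still. As far as these compounds go, these read-outs come from one concentration and are not potencies, so how the compounds would rank across a range of concentrations also remains open.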